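Chloro to Fluoro on the Benzyl Ring: Cytotoxicity Outlook

This account rests on a few compounds, and the source may have more. Where it says the series, first, only, none or still open, it means among the compounds named here.

Compound 2 `CC(=O)Oc1ccc2c(c1)C(C)=CC(C)(C)N2Cc1ccc(Cl)cc1` gives 22000 nM in an ADME assay on L6 cells (Rattus norvegicus) for cytotoxicity, read by resazurin assay, with a stated time of 70 h (on this read-out higher numbers stand for weaker inhibition and lower numbers for stronger inhibition), the higher of the two numbers in hand. Compound 1 `CC1=CC(C)(C)N(Cc2ccc(Cl)cc2)c2ccc(O)cc21` gives 7900 nM in this assay. Going by the values given here, the one measured step, a 2.8-fold higher number from compound 1 to compound 2 (0.44 log units; beyond the scatter), concerns an acetyl on an oxygen and says nothing about the halogen on the benzyl ring. Compound 3 `CC(=O)Oc1ccc2c(c1)C(C)=CC(C)(C)N2Cc1ccc(F)cc1` differs from compound 2 by fluoro in place of chloro on an aromatic carbon. Among the compounds with values here, no measured step bears on this change, so compound 3 is expected to sit within the scatter of compound 2. The expected step is no change at the digits printed from compound 2 to compound 3 (within the scatter). Compound 3 is estimated at 22000 nM, between 8000 nM and 60000 nM.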

Compound 3, half-maximal inhibitory concentration: 29000 nM
For compound 3 the middle estimate is 1.3-fold (0.12 log units) below the measured one; the range from low to high includes it.
By their numbers in this assay, from the lowest: compound 1; then compounds 2 and 3 (each within the scatter of the next).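

Going from 4-chlorobenzyl to 4-fluorobenzyl gives a 1.3-fold higher number from compound 2 to compound 3 (0.12 log units; within the scatter) in this assay. Going by these compounds alone, the earlier step touched only the acetyl on the oxygen, so this is the first reading at the halogen on the benzyl ring, and here chloro and fluoro cannot be told apart. Nothing measured here offers a reason for this result.

From the compounds shown here alone, whether fluoro in place of chloro would read the same on compound 1 stays open. Also open, going by these compounds, is what an amine or a carboxylic acid on that aromatic carbon would give.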